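Changing the Group on a Ring Nitrogen

The source may report more compounds than this note shows. Statements on the series, on what has been measured and on what is new or still open speak of the compounds shown alone.

Of the compounds shown here, three built on one shared core have been tested in a functional assay on DU-145 cells (Homo sapiens) for inhibition, read by MTT assay, with a stated time of 24 h; a lower number here means a stronger inhibitor, a higher number a weaker inhibitor. Compound 1 `O=C(O)C1=Cc2ccccc2OC1(OCc1cc(-c2ccc(F)cc2)no1)C(F)(F)F` gives 168000 nM. Compound 2 `CCOC(=O)C1=Cc2ccccc2OC1(OCc1cc(-c2ccc(OC)cc2)no1)C(F)(F)F` reaches only a limit of the assay, > 150000 nM. Compound 3 `CCOC(=O)C1=Cc2ccccc2OC1(OCc1cn(-c2ccc(C)cc2)nn1)C(F)(F)F` gives 30200 nM, the lowest of the two numbers shown, with compound 1 the nearest to it and that gap beyond the scatter. Compound 4 `CCOC(=O)C1=Cc2ccccc2OC1(OCc1cn(CC(=O)Nc2ccccc2Br)nn1)C(F)(F)F` has not yet been measured. It differs from compound 3 in one place: ((2-bromophenyl)carbamoyl)methyl in place of 4-methylphenyl on an aromatic nitrogen. For the measured compounds named here, no measured pair here shows what such a change does, so the step is expected to stay within the scatter, a 1.2-fold higher number from compound 3 to compound 4 (0.06 log units; within the scatter). Compound 4 is therefore estimated at 35000 nM, with a likely range from 8000 nM to 150000 nM.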

Compound 4, half-maximal inhibitory concentration: > 150000 nM
Compound 4: no number, only a limit; the forecaster's own chance of this, stated with the estimate: 25%; middle value at least 4.2-fold (0.63 log units) from the limit.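

The group on this aromatic nitrogen clearly matters: ((2-bromophenyl)carbamoyl)methyl in place of 4-methylphenyl gives an at least 4.9-fold higher number from compound 3 to compound 4 (0.69 log units; beyond the scatter). The entering group is larger and adds a hydrogen-bond donor and acceptor, but this single change cannot show which of these features goes with the weaker result. Compound 4 gives only a limit of the assay, > 150000 nM, so the full size of the step cannot be read: the limit of > 150000 nM in this assay, at which 2 of the 4 values shown sit.

Still open, going by these compounds, is how a benzyl group or a plain ethyl chain on this nitrogen would compare with 4-methylphenyl. Also open, on these data alone, is whether the same carbamoyl chain without the bromine would behave differently.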